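This account rests on a few compounds, and the source may have more. Where it says the series, first, only, none or still open, it means among the compounds named here.

The measured compounds:
compound 1, `C=C1C[C@]23C[C@@]1(O)CC[C@@H]2c1cccc(C)c1[C@@H]3Cn1cc(-c2ccc(Br)cc2)nn1`: > 20000 nM
compound 2, `C=C1C[C@]23C[C@@]1(O)CC[C@H]2c1ccc(OS(=O)(=O)c2ccc(C)cc2)c(C)c1[C@@H]3Cn1cc(-c2ccccc2)nn1`: > 20000 nM

In a functional assay on MCF7 cells (Homo sapiens) for cytotoxicity, read by MTT assay, with a stated time of 4 days (on this read-out lower numbers stand for stronger inhibition and higher numbers for weaker inhibition), compound 1 gives > 20000 nM, which is a limit of the assay and not a number. Compound 2 likewise gives only > 20000 nM, again a limit. Among the compounds with values here, both values sit at the limit of > 20000 nM in this assay, at which 2 of the 2 values shown sit, so compound 1 stands level with the only other measured compound, and no order between the two can be read from these figures. Within the data shown here, no step between measured compounds can be drawn here.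

The compound still to be measured is compound 3, `C=C1C[C@]23C[C@@]1(O)CC[C@@H]2c1cccc(C)c1[C@@H]3Cn1cc(-c2ccccn2)nn1`. It differs from compound 1 in one place: pyridin-2-yl in place of 4-bromophenyl on an aromatic carbon. Among the measured compounds shown here, since both measured compounds sit at the limit of > 20000 nM in this assay, at which 2 of the 2 values shown sit, there is no measured step on which to gauge this exchange, and the expected step that the limit leaves unreadable from compound 1 to compound 3 is none beyond the scatter. Compound 3 is therefore estimated at 25000 nM, within the range 8000 nM to 80000 nM, and most probably the assay will again report only a limit for it.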

Compound 3, half-maximal inhibitory concentration: > 20000 nM
Compound 3 ended at the assay's limit (the forecaster's own chance of this, stated with the estimate: 75%); the middle value lies beyond the limit too.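

Compound 1 and compound 3 both end at a limit of the assay in this assay, so no step can be read for pyridin-2-yl in place of 4-bromophenyl: the limit of > 20000 nM in this assay, at which 3 of the 3 values shown sit. The compounds shown leave open how far each lies beyond that limit, and whether this exchange alters the result in this assay at all.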